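This account rests on a few compounds, and the source may have more. Where it says the series, first, only, none or still open, it means among the compounds named here.

Of the compounds shown here, three sharing one core have been tested in a functional assay on cells (Cancer cell lines, Homo sapiens) for cytotoxicity, read by sulforhodamine B assay, with a stated time of 48 h; on this read-out lower numbers stand for stronger inhibition of growth and higher numbers for weaker inhibition of growth. Compound 1 `Oc1ccc(O)c(-c2cc(-c3ccccc3)nn2-c2ccccc2)c1` gives 63700 nM, compound 2 `Oc1ccc(O)c(-c2cc(-c3ccc(Cl)cc3)nn2-c2ccccc2)c1` gives 33200 nM, and compound 3 `NS(=O)(=O)c1ccc(-n2nc(-c3ccc(Cl)cc3)cc2-c2cc(O)ccc2O)cc1` gives 39100 nM. Compound 2 holds the lowest of the three numbers, though its gaps to compound 3 and to compound 1 both stay within the scatter. Compound 4 `O=C1C=CC(=O)C(c2cc(-c3ccc(Cl)cc3)nn2-c2ccccc2)=C1` differs from compound 2 in that (a group of 8 heavy atoms (6 carbon, 2 oxygen; one six-membered non-aromatic ring of carbon only) in place of a group of 8 heavy atoms (6 carbon, 2 oxygen; one six-membered aromatic ring of carbon only), on an aromatic carbon). Neither measured step touches this part of the molecule: a 1.9-fold lower number from compound 1 to compound 2 (0.28 log units; within the scatter) and a 1.2-fold higher number from compound 2 to compound 3 (0.07 log units; within the scatter) concern other groups and both stayed within the scatter. Among the measured compounds shown here, with no step that bears on the change, no shift beyond the scatter is expected in this assay, so the expected 1.1-fold lower number from compound 2 to compound 4 (0.04 log units; within the scatter) is small. Compound 4 is therefore estimated at 30000 nM, in a range from 8000 nM to 100000 nM.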

Compound 4, concentration for total growth inhibition: 70100 nM
Compound 4: the middle estimate sits 2.3-fold (0.37 log units) below what was measured; low and high end bracket the measured number.
By their numbers in this assay, from the lowest: compounds 2, 3, 1 and 4 (each within the scatter of the next, the first and the last beyond it).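

In this assay, among the compounds shown here, replacing the 2,5-dihydroxyphenyl group with the non-aromatic six-membered carbon ring gives a 2.1-fold higher number from compound 2 to compound 4 (0.32 log units; beyond the scatter) and is the first step to lie beyond the scatter. This position therefore responds to a change that the chloro and sulfamoyl steps elsewhere in the molecule did not reveal, although the shift is modest. No measurement given here explains the shift. The compounds shown leave open how an amine or a carboxylic acid would read at this position. They also leave open whether the same replacement would give a similar step with the sulfamoyl group of compound 3 present.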